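This account rests on a few compounds, and the source may have more. Where it says the series, first, only, none or still open, it means among the compounds named here.

Working notes on the series. In a functional assay (Mus musculus, strain BALB/C) for inhibition, read by MTT assay, with stated times of 24 h and 72 h (on this read-out higher numbers stand for weaker inhibition and lower numbers for stronger inhibition), compound 1 `Cc1ccc(C(=O)N/N=C/c2ccccc2F)c(O)c1` gives 42100 nM. Compound 2 `Cc1ccc(C(=O)N/N=C/c2ccccc2[N+](=O)[O-])c(O)c1` reaches a limit of the assay, > 100000 nM. Compound 3 `Cc1ccc(C(=O)N/N=C/c2ccc(F)cc2)c(O)c1` gives 26700 nM in this assay, within the scatter of compound 1, so no order between these two is drawn. The difference between the cores of compound 1 and compound 3 is not broken down here. From compound 1 to compound 2 the change is nitro in place of fluoro on an aromatic carbon, and it gave an at least 2.3-fold higher number from compound 1 to compound 2 (0.37 log units; beyond the scatter); the size of that step is set by the limit of > 100000 nM in this assay, at which 1 of the 3 values shown sits. Compound 4 `Cc1ccc(C(=O)N/N=C/c2ccc([N+](=O)[O-])cc2)c(O)c1` carries the same kind of change against compound 3, (nitro in place of fluoro on an aromatic carbon), with the place differing: ortho to a large group in the first pair, para to a large group in the second. Resting on an at least 2.3-fold higher number from compound 1 to compound 2 (0.37 log units; beyond the scatter), the step now expected is a 3.0-fold higher number from compound 3 to compound 4 (0.48 log units; beyond the scatter). Compound 4 is accordingly estimated at 80000 nM, with a range from 35000 nM to 200000 nM.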

Compound 4, half-maximal inhibitory concentration: 24300 nM
Beside the measured number, compound 4's estimate is 3.3-fold (0.52 log units) above it; the whole stated range lies above it.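

In this assay, nitro in place of fluoro para to a large group gives a 1.1-fold lower number from compound 3 to compound 4 (0.04 log units; within the scatter), while the same swap ortho to a large group gives an at least 2.3-fold higher number from compound 1 to compound 2 (0.37 log units; beyond the scatter). The step read beyond the scatter on the core of compound 1 therefore does not reappear as a step beyond the scatter on the core of compound 3, but this does not show that the two steps differ: the same change on two cores in this assay, an at least 2.3-fold higher number (0.37 log units; beyond the scatter) from compound 1 to compound 2 and a 1.1-fold lower number (0.04 log units; within the scatter) from compound 3 to compound 4; the limit leaves it open whether they differ Compound 2 stands at a limit, not at a number: the limit of > 100000 nM in this assay, at which 1 of the 4 values shown sits.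

The compounds shown leave open how an amine or a carboxylic acid in the place of fluoro or nitro would read in this assay. They also leave open whether the swap would read alike on further cores.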